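The source may report more compounds than this note shows. Statements on the series, on what has been measured and on what is new or still open speak of the compounds shown alone.

Of the compounds shown here, two have so far been measured in a functional assay on Caco-2 cells (Homo sapiens) for antiproliferative activity, read by sulforhodamine B assay, with a stated time of 48 h; a lower number here means a stronger inhibitor, a higher number a weaker inhibitor. Compound 1 `COc1cc(NC(C)CCCN2C(=O)[C@H](C)NC2(C)C)c2ncccc2c1` gives 71000 nM in this assay. Compound 2 `COc1cc(NC(C)CCCN2C(=O)CN(C(=O)[C@H](C)N)C2(C)C)c2ncccc2c1` carries a further acyl group on the ring nitrogen, and in this assay compound 2 gives > 100000 nM, which is a limit of the assay and not a number. Compound 2 thus sits at the limit of > 100000 nM in this assay, at which 1 of the 2 values shown sits, and no numerical value for it is known.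

Compound 3 `COc1cc(NC(C)CCCN2C(=O)CN(C(C)=O)C2(C)C)c2ncccc2c1` has not yet been measured. It differs from compound 2 by methyl in place of 1-aminoethyl on a carbonyl carbon; in other words, the acyl group on the ring nitrogen changes from (1-aminoethyl)carbonyl to acetyl. Within the data shown here, no step between measured compounds shows this kind of change, so nothing measured points to a direction. Since compound 2 stands only at a limit, the expectation for compound 3 is a step of about a number no higher from compound 2 to compound 3 (the limit leaves the size open), none beyond the scatter. Compound 3 is therefore estimated to give 100000 nM in this assay, with a range from 40000 nM to 250000 nM.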

Compound 3, half-maximal inhibitory concentration: 60000 nM
The estimate for compound 3 lay 1.7-fold (0.22 log units) above the measured number, and the stated range covers the measured number.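

In this assay compound 3 gives 60000 nM, so a compound with an acyl group on the ring nitrogen now has a number. Methyl in place of 1-aminoethyl on a carbonyl carbon gives an at least 1.6-fold lower number from compound 2 to compound 3 (0.22 log units; that floor lies within the scatter), the first reading of this change at this place, and that reading does not by itself establish a real difference between the two groups. How large the step truly is stays unknown because compound 2 has a limit of the assay and not a number: the limit of > 100000 nM in this assay, at which 1 of the 3 values shown sits.

The compounds shown leave open whether any difference belongs to the amine of the 1-aminoethyl group, to its carbon part or to its defined stereocentre, and an ethyl group or an aminomethyl group on the same carbonyl carbon would begin to separate these. They also leave open how a longer chain, or a chain ending in a carboxylic acid, would read at this place in this assay.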